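The compounds below may be only part of what the source reports. "The series", "measured", "known", "first", "only" and "open" are said of these compounds alone.

The study gathers three measured compounds on a shared core. Compound 1 `NC(=O)C[C@H](NC(=O)CN(c1nc(Cl)nc2c1ncn2C1CCCCO1)C1CC1)C(=O)OCc1ccccc1` in a functional assay on the whole organism with Mus musculus as the target, with a stated time of 90 min, at a dose of 25 umol/kg by the oral route (on this read-out lower numbers stand for a weaker effect and higher numbers for a stronger effect at the one dose given), gives 35%. Compound 2 `O=C(CN(c1nc(Cl)nc2c1ncn2C1CCCCO1)C1CC1)N[C@@H](CC(=O)OCc1ccccc1)C(=O)OCc1ccccc1` gives 25.1%, and compound 3 `CC(C)(C)OC(=O)NCCCC[C@H](NC(=O)CN(c1nc(Cl)nc2c1ncn2C1CCCCO1)C1CC1)C(=O)OCc1ccccc1` gives 32.9%. Among these three numbers compound 3 stands second highest, yet the separation a number 2.1 percentage points lower from compound 1 to compound 3 (within the scatter) and the separation a number 7.8 percentage points higher from compound 2 to compound 3 (within the scatter) both lie within the scatter, as does a number 9.9 percentage points lower from compound 1 to compound 2 (within the scatter), so the three variants of the group on the saturated chain carbon cannot be told apart on these data.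

Compound 4 `CC(C)[C@H](NC(=O)CN(c1nc(Cl)nc2c1ncn2C1CCCCO1)C1CC1)C(=O)OCc1ccccc1` is not yet measured. It differs from compound 3 in one place: isopropyl in place of 4-((tert-butoxycarbonyl)amino)butyl on a saturated chain carbon bound to an amide-type nitrogen and a carbonyl carbon. The measured steps that bear on this change are the two that altered the group on the same saturated chain carbon, namely a number 2.1 percentage points lower from compound 1 to compound 3 (within the scatter) and a number 7.8 percentage points higher from compound 2 to compound 3 (within the scatter), each within the scatter. On that basis no step beyond the scatter is expected in this assay, in either direction. Compound 4 is therefore estimated at 32%, with a range from 20% to 44%. The expected step is a number 0.9 percentage points lower from compound 3 to compound 4 (within the scatter).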

Compound 4, a percentage reported as activity, at one dose (the size of the read-out at that dose, not a potency): 30.1%
Beside the measured number, compound 4's estimate is 1.9 percentage points above it; the range from low to high includes it.
By their numbers in this assay, from the lowest: compounds 2, 4, 3 and 1 (each within the scatter of the next).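

In this assay, the saturated chain carbon bound to an amide-type nitrogen and a carbonyl carbon also accepts isopropyl, with 3 heavy atoms and no hydrogen-bond donors or acceptors, in place of 4-((tert-butoxycarbonyl)amino)butyl, with 12 heavy atoms, and the result is a number 2.8 percentage points lower from compound 3 to compound 4 (within the scatter). The other two comparisons read the same way, with a number 5 percentage points higher from compound 2 to compound 4 (within the scatter) and a number 4.9 percentage points lower from compound 1 to compound 4 (within the scatter), so a group without a carbonyl, unlike the three earlier groups, still cannot be told apart from them. No evidence on the origin of this result is available.

The compounds leave open whether a primary amine at the end of a butyl chain on this carbon would give a step beyond the scatter. They also leave open what a carboxylic acid would give in place of the benzyl ester that all four carry.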